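From dimethylcarbamoyl to (pyrrolidin-1-yl)carbonyl

This account rests on a few compounds, and the source may have more. Where it says the series, first, only, none or still open, it means among the compounds named here.

Compound 1 `CC(C)=CCC[C@]1(C)/C=C/[C@@H](OC(=O)C=C(C)C)[C@](C)(O)/C=C/C(=O)/C(C[Si](C)(C)C(C)(C)C)=C\C1`: 4200 nM
Compound 2 `CC(C)=CCC[C@]1(C)/C=C/[C@@H](OC(=O)C=C(C)C)[C@](C)(O)/C=C/C(=O)/C(CN=[N+]=[N-])=C\C1`: 1720 nM
Compound 3 `CC(C)=CCC[C@]1(C)/C=C/[C@@H](OC(=O)C=C(C)C)[C@](C)(O)/C=C/C(=O)/C(C(=O)N(C)C)=C\C1`: 2700 nM

In a functional assay on A549 cells (Homo sapiens) for antiproliferative activity, read by MTT assay, with a stated time of 48 h (on this read-out lower numbers stand for stronger inhibition and higher numbers for weaker inhibition), compound 3 gives 2700 nM, and it is not separated from either of the other two compounds. The data show a 1.6-fold lower number from compound 1 to compound 3 (0.19 log units; within the scatter) and a 1.6-fold higher number from compound 2 to compound 3 (0.20 log units; within the scatter).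

Compound 4 `CC(C)=CCC[C@]1(C)/C=C/[C@@H](OC(=O)C=C(C)C)[C@](C)(O)/C=C/C(=O)/C(C(=O)N2CCCC2)=C\C1` has not yet been measured. It carries pyrrolidin-1-yl in place of dimethylamino on a carbonyl carbon.

Among the measured compounds shown here, no measured pair isolates this change. The nearest evidence is a 1.6-fold higher number from compound 2 to compound 3 (0.20 log units; within the scatter), a replacement of the whole group on the double-bonded ring carbon that stayed within the scatter. For the measured compounds named here, the one step beyond the scatter, a 2.4-fold lower number from compound 1 to compound 2 (0.39 log units; beyond the scatter), is modest and falls on a saturated chain carbon, so it bears on this change only loosely.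

No shift beyond the scatter is therefore expected in this assay. The expected step is a 1.1-fold lower number from compound 3 to compound 4 (0.03 log units; within the scatter). For compound 4 the estimated value is 2500 nM, with an expected range of 1200 nM to 5500 nM.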

Compound 4, half-maximal inhibitory concentration: 13000 nM
Compound 4: middle estimate off by 5.2-fold (0.72 log units), on the low side; the whole stated range lies below it.
By their numbers in this assay, from the lowest: compounds 2, 3 and 1 (each within the scatter of the next, the first and the last beyond it); then compound 4.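

In this assay the step of a 4.8-fold higher number from compound 3 to compound 4 (0.68 log units; beyond the scatter) shows that this position responds to the amine part of the amide alone, with the carbonyl kept in place on the double-bonded ring carbon. The change also sets compound 4 apart from the other two compounds, with a 7.6-fold higher number from compound 2 to compound 4 (0.88 log units; beyond the scatter) and a 3.1-fold higher number from compound 1 to compound 4 (0.49 log units; beyond the scatter) as the further steps, so compound 4 is the weakest of the four. A carbonyl on this ring carbon therefore does not fix the number by itself, since the group on that carbonyl carries the difference.

Nothing shown here accounts for this step. From the compounds shown here alone, it stays open whether a diethylamino, a piperidin-1-yl or a morpholin-4-yl group on the same carbonyl carbon would stand with compound 3 or with compound 4.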